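The source may hold more compounds than are shown below. What is called first, only, known or untested is meant among the compounds shown, and "the series" means these compounds.

Three compounds share one core and differ in the group attached to it. Compound 1 `COc1cc2c(Oc3ccc(NC(=O)c4cc(-c5ccccc5)nc5ccccc45)cc3F)ccnc2cc1OCCCN1CCCCC1` carries a phenyl there, and in a functional assay on NCI-H460 cells (Homo sapiens) for cytotoxicity, read by MTT assay, with a stated time of 72 h (on this read-out higher numbers stand for weaker inhibition and lower numbers for stronger inhibition), compound 1 gives 110 nM. Compound 2 `COc1ccc(-c2cc(C(=O)Nc3ccc(Oc4ccnc5cc(OCCCN6CCCCC6)c(OC)cc45)c(F)c3)c3ccccc3n2)cc1` carries a 4-methoxyphenyl instead, and in this assay compound 2 gives 290 nM. Compound 3 `COc1cc2c(Oc3ccc(NC(=O)c4cc(-c5ccc(Cl)c(Cl)c5)nc5ccccc45)cc3F)ccnc2cc1OCCCN1CCCCC1` carries a 3,4-dichlorophenyl, and in this assay compound 3 gives 820 nM. The step of a 2.6-fold higher number from compound 1 to compound 2 (0.42 log units; beyond the scatter) went with methoxy in place of hydrogen on an aromatic carbon; the step of a 7.5-fold higher number from compound 1 to compound 3 (0.87 log units; beyond the scatter) went with 3,4-dichlorophenyl in place of phenyl on an aromatic carbon; the step of a 2.8-fold higher number from compound 2 to compound 3 (0.45 log units; beyond the scatter) went with 3,4-dichlorophenyl in place of 4-methoxyphenyl on an aromatic carbon. Compound 3 thus stands with the highest number of the three, beyond the scatter from both others.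

Compound 4 `COc1cc2c(Oc3ccc(NC(=O)c4cc(-c5ccc(Cl)c(Cl)c5)nc5ccccc45)cc3F)ccnc2cc1OCCCN1CCCC1` keeps the 3,4-dichlorophenyl and changes a different part of the molecule: pyrrolidin-1-yl in place of piperidin-1-yl on a saturated chain carbon, three bonds along the chain from an oxygen on an aromatic ring. None of the three measured steps touches this chain end; all of them alter the aromatic group. Among the compounds with values here, no measured step therefore bears on this change, and the expected step of a 1.0-fold lower number from compound 3 to compound 4 (0.01 log units; within the scatter) is estimated to stay within the scatter. Compound 4 is expected to give 800 nM, with a range from 300 nM to 2200 nM.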

Compound 4, half-maximal inhibitory concentration: 400 nM
Compound 4: middle estimate off by 2.0-fold (0.30 log units), on the high side; the measured number falls inside the stated range.
By their numbers in this assay, from the lowest: compound 1; then compounds 2 and 4 (each within the scatter of the next); then compound 3.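

In this assay the swap from piperidin-1-yl to pyrrolidin-1-yl gives a 2.1-fold lower number from compound 3 to compound 4 (0.31 log units; beyond the scatter) and so shows that the end of the chain, which none of the earlier changes to the aromatic group touched, can also shift the number beyond the scatter, even though the two rings differ by only one carbon. The step is modest and rests on a single pair of compounds that both carry the 3,4-dichlorophenyl, so it describes this change in this one setting and is not yet a general rule for the chain end. No evidence is available to explain why the number moves with this change.

The compounds shown leave open how a morpholin-4-yl or a dimethylamino group would compare at this chain end, and whether a shorter 2-(pyrrolidin-1-yl)ethyl chain or a longer chain would move the number further. They also leave open whether pyrrolidin-1-yl would give a similar step alongside the phenyl of compound 1 or the 4-methoxyphenyl of compound 2.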